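From 3-Chlorophenyl to 4-Chlorophenyl on a Shared Core

The source may hold more compounds than are shown below. What is called first, only, known or untested is meant among the compounds shown, and "the series" means these compounds.

Three compounds share one core: compound 1 `Fc1ccccc1Cn1ccc2nc(-c3ccccc3)nc-2c1`, compound 2 `Clc1cccc(Cn2ccc3nc(-c4ccccc4)nc-3c2)c1` and compound 3 `Clc1ccc(Cn2ccc3nc(-c4ccccc4)nc-3c2)cc1`. In an ADME assay on MDBK cells (Bos taurus) for cytotoxicity (on this read-out lower numbers stand for higher toxicity in this test and higher numbers for lower toxicity in this test), compound 1 gives > 100000 nM, which is a limit of the assay and not a number. In this assay compound 2 gives > 100000 nM, which is also only a limit. Compound 2 therefore has no exact position on the scale, and the whole record so far is the limit of > 100000 nM in this assay, at which 2 of the 2 values shown sit.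

The move to compound 3 keeps the same atoms but joins them differently: 4-chlorophenyl in place of 3-chlorophenyl on a saturated chain carbon bound to an aromatic nitrogen. In words, 4-chlorophenyl stands in place of 3-chlorophenyl on a saturated chain carbon bound to an aromatic nitrogen.

Going by the values given here, the one measured step at this place is a step that the two limits leave unreadable from compound 1 to compound 2, so it offers no size to carry over. On that basis, compound 3 is expected to show no change beyond the scatter in this assay, and no direction can be named. The estimated change is a number no higher from compound 2 to compound 3 (the limit leaves the size open). Compound 3 is estimated at 100000 nM, with an expected range of 50000 nM to 200000 nM, and the assay may well report only a limit again.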

Compound 3, half-maximal cytotoxic concentration: > 100000 nM
Compound 3 was reported as a limit; the forecaster's own chance of this, stated with the estimate: 85%; the middle value sits exactly at the limit.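

Compound 3 also returns only a limit of the assay, so no step among compound 1, compound 2 and compound 3 can be read in this assay, and all three stand at the same mark: the limit of > 100000 nM in this assay, at which 3 of the 3 values shown sit.

The compounds shown leave open where the actual half-maximal cytotoxic concentration of each lies, and whether exchanging 2-fluorophenyl, 3-chlorophenyl and 4-chlorophenyl changes it at all.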